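Replacing the side chain of compound 2

A few compounds are considered here, and "the series" means these few. Any claim that something is new, unique, unknown or untested is made for them only; others in the source may bear on it.

In a functional assay on PC-3 cells (Homo sapiens) for inhibition, read by MTT assay, with a stated time of 48 h, tested at 10 uM (a lower number here means less inhibition of growth, a higher number more inhibition of growth at the concentration tested), compound 2 (`Cc1cc(=O)c2c(O)c(CN(C)CC(=O)O)c(O)c([C@H]3CCN(C)C[C@H]3O)c2o1`) stands highest of the two measured compounds, giving 20% against compound 1 (`CCN(CC)Cc1c(O)c([C@H]2CCN(C)C[C@H]2O)c2oc(C)cc(=O)c2c1O`) at 2% for comparison. Within the data shown here, the single measured step concerns the same place, a saturated chain carbon bound to an aromatic carbon, and it is modest: a number 18 percentage points higher from compound 1 to compound 2 (beyond the scatter) when (carboxymethyl)(methyl)amino replaces diethylamino. Compound 3 (`CCOC(=O)N1CCN(Cc2c(O)c([C@H]3CCN(C)C[C@H]3O)c3oc(C)cc(=O)c3c2O)CC1`) changes that place again, and 4-(ethoxycarbonyl)piperazin-1-yl in place of (carboxymethyl)(methyl)amino on a saturated chain carbon bound to an aromatic carbon is its whole difference. Among the measured compounds shown here, compound 3 no longer holds the group that came with the rise in compound 2 to 20% so part of that rise may be lost, although no measured compound carries the new group. A small fall is expected, namely a number 9 percentage points lower from compound 2 to compound 3 (within the scatter) in this assay and perhaps no more than the usual scatter. For compound 3 the estimate is 11% with an expected range from 0% to 28% of inhibition.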

Compound 3, percent growth inhibition at one concentration: 1%
Beside the measured number, compound 3's estimate is 10 percentage points above it; measured number inside the range.
By their numbers in this assay, from the lowest: compounds 3 and 1 (each within the scatter of the next); then compound 2.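

At this position, the rise seen with compound 2 does not carry over to every replacement of diethylamino: in this assay, 4-(ethoxycarbonyl)piperazin-1-yl in place of (carboxymethyl)(methyl)amino gives a number 19 percentage points lower from compound 2 to compound 3 (beyond the scatter). The larger ring-bearing group also gives a number 1 percentage points lower from compound 1 to compound 3 (within the scatter), so in this small set it reads the same as diethylamino, and only compound 2 stands apart. Nothing available explains why these groups differ in this way.

Still open, going by these compounds, is whether the carboxylic acid of compound 2 itself goes with the higher number, which an ethyl ester or primary amide on the same chain could test. A piperazine with a free amine in place of the ethoxycarbonyl-bearing ring could likewise show whether the ring or its ethoxycarbonyl group goes with the lower number.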